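Cytotoxicity notes on compounds 1 to 3

The source may report more compounds than this note shows. Statements on the series, on what has been measured and on what is new or still open speak of the compounds shown alone.

Measured so far:
Compound 1, `Cc1ccc(-c2cnc(Nc3ccc(C#N)cc3)nc2Oc2c(C)cc(C#N)cc2C)cc1`: 26100 nM
Compound 2, `Cc1cc(C#N)cc(C)c1Oc1nc(Nc2ccc(C#N)cc2)ncc1-c1ccc(C(F)(F)F)cc1`: 35000 nM

In an ADME assay on MT4 cells (Homo sapiens) for cytotoxicity, read by MTT assay, with a stated time of 5 days (on this read-out higher numbers stand for lower toxicity in this test and lower numbers for higher toxicity in this test), compound 2 gives the highest of the two numbers; the nearest is compound 1, and the step of a 1.3-fold higher number from compound 1 to compound 2 (0.13 log units; within the scatter) lies within the scatter, so the two cannot be ordered.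

Compound 3, `Cc1cc(C#N)cc(C)c1Oc1nc(Nc2ccc(C#N)cc2)ncc1-c1cncnc1`, has not been measured. It differs from compound 2 in one place: pyrimidin-5-yl in place of 4-(trifluoromethyl)phenyl on an aromatic carbon.

Within the data shown here, the only measured step, a 1.3-fold higher number from compound 1 to compound 2 (0.13 log units; within the scatter), concerns an exchange of methyl for trifluoromethyl on the same aromatic carbon, and it stayed within the scatter. Among the measured compounds shown here, no measured step exchanges the whole ring at that position for pyrimidin-5-yl, so the present change has no direct precedent in the data. On that basis no step beyond the scatter is expected in this assay; the estimated step of a 1.1-fold higher number from compound 2 to compound 3 (0.04 log units; within the scatter) is meant as essentially flat. Compound 3 is therefore expected to give about 38000 nM, with a range from 15000 nM to 100000 nM.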

Compound 3, half-maximal cytotoxic concentration: > 298000 nM
Compound 3 gave a limit, no number; the forecaster's own chance of this, stated with the estimate: 30%; at least 7.8-fold (0.89 log units) between middle value and limit.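

In this assay, among these compounds, the earlier compounds showed only that exchanging a group on the outer ring at this position changed little: a 1.3-fold higher number from compound 1 to compound 2 (0.13 log units; within the scatter). Exchanging the whole ring behaves differently, since replacing 4-(trifluoromethyl)phenyl with pyrimidin-5-yl gives an at least 8.5-fold higher number from compound 2 to compound 3 (0.93 log units; beyond the scatter), and replacing 4-methylphenyl with the same ring gives an at least 11-fold higher number from compound 1 to compound 3 (1.05 log units; beyond the scatter), so both carbon-only rings shown lead to the same direction of step, beyond the scatter, once pyrimidin-5-yl enters at this carbon. Compound 3 stands at a limit of the assay and not at a number: the limit of > 298000 nM in this assay, at which 1 of the 3 values shown sits.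

The compounds shown leave open whether the step follows the two ring nitrogens of pyrimidin-5-yl or the absence of any group on the outer ring, a question that a plain phenyl or a pyridin-3-yl at this carbon would separate. Also open, as far as these compounds go, is how far the number of compound 3 lies past its limit, and whether an amine or a carboxylic acid on the outer ring would move the read-out in the same direction as pyrimidin-5-yl.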